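The source may hold more compounds than are shown below. What is called first, only, known or untested is meant among the compounds shown, and "the series" means these compounds.

Measured so far in a physicochemical assay for pharmacokinetics, at pH 1, tested at 100 ug/mL; on this read-out higher numbers stand for a longer-lived compound and lower numbers for a shorter-lived compound:
Compound 1 `NCCSNC(=O)[C@@H](CCC(F)(F)F)N(Cc1ccc(-c2ncon2)cc1F)S(=O)(=O)c1ccc(Cl)cc1`: > 500 h
Compound 2 `N[C@@H](CSNC(=O)[C@@H](CCC(F)(F)F)N(Cc1ccc(-c2ncon2)cc1F)S(=O)(=O)c1ccc(Cl)cc1)C(=O)O`: > 500 h
Compound 3 `O=C(NSc1ccccc1)[C@@H](CCC(F)(F)F)N(Cc1ccc(-c2ncon2)cc1F)S(=O)(=O)c1ccc(Cl)cc1`: > 500 h

Compound 2 gives > 500 h, which is a limit of the assay and not a number. Among the measured compounds shown here, the series so far shows (the limit of > 500 h in this assay, at which 3 of the 3 values shown sit), so no measured compound can be ranked against another.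

The next compound is compound 4 `CCOC(=O)[C@@H](N)CSNC(=O)[C@@H](CCC(F)(F)F)N(Cc1ccc(-c2ncon2)cc1F)S(=O)(=O)c1ccc(Cl)cc1`. It differs from compound 2 by ethyl in place of hydrogen on an oxygen next to a carbonyl group, which turns carboxy into ethoxycarbonyl.

For the measured compounds named here, no measured step makes this change. The nearest is a step that the two limits leave unreadable from compound 1 to compound 2, which brings in the carboxy group that compound 4 alters. The other two, a step that the two limits leave unreadable from compound 1 to compound 3 and a step that the two limits leave unreadable from compound 2 to compound 3, replace the whole group on the sulfur. None of the three has a readable size, so they offer no measure of the new step and no direction for it.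

The expectation in this assay therefore rests only on compound 2 and on the limit of > 500 h in this assay, at which 3 of the 3 values shown sit: no step beyond the scatter, with a further report at the limit the likeliest result. The expected outcome is a number no higher from compound 2 to compound 4 (the limit leaves the size open). For compound 4 the estimate is 500 h, with an expected range of 200 h to 1000 h.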

Compound 4, half-life: > 500 h
Compound 4 ended at the assay's limit; the forecaster's own chance of this, stated with the estimate: 65%; the middle value sits exactly at the limit.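

In this assay compound 4 gives > 500 h as a limit of the assay and not a number. No step from compound 1, compound 2 or compound 3 to compound 4 can be read, so none of these compounds can be ranked. The compounds shown leave open whether carboxy to ethoxycarbonyl, or any change of the group on the sulfur, alters the half-life.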